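This account rests on a few compounds, and the source may have more. Where it says the series, first, only, none or still open, it means among the compounds named here.

Three measured compounds set the scene. Compound 1 `COc1cc(C(C)=O)ccc1OCCCN1CCC(C(c2ccc(F)cc2F)c2ccc(F)cc2F)CC1` gives in a functional assay (aorta) with Oryctolagus cuniculus as the target (on this read-out lower numbers stand for tighter binding and higher numbers for weaker binding), a value of 15.9 nM. Compound 2 `COc1ccc(C(c2ccc(OC)cc2)C2CCN(CCCOc3ccc(C(C)=O)cc3OC)CC2)cc1` gives in this assay a value of 10 nM. Compound 3 `CCc1ccc(OCCCN2CCC(C(c3ccc(F)cc3)c3ccc(F)cc3)CC2)c(OC)c1` gives in this assay a value of 2.51 nM, the lowest of the three, and both of its gaps to the other two lie beyond the usual scatter, so it binds the tightest of this small set.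

Compound 4 `Fc1ccc(C(c2ccc(F)cc2)C2CCN(CCCCc3ccccc3)CC2)cc1` has not yet been measured. It differs from compound 3 in one place: benzyl in place of 4-ethyl-2-methoxyphenoxy on a saturated chain carbon, three bonds along the chain from an amine nitrogen in a ring. The group that leaves carries two hydrogen-bond acceptors and an ethyl on its ring; the group that enters carries neither. For the measured compounds named here, no measured pair shows this exact change, so the size of the step rests on judgment alone. Removing these features from the tightest binder of the set is expected to loosen binding, with a step from compound 3 to compound 4 of about a 4.0-fold higher number from compound 3 to compound 4 (0.60 log units; beyond the scatter). Compound 4 is therefore estimated at 10 nM in this assay, within a range of 3 nM to 40 nM.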

Compound 4, dissociation constant: 2.51 nM
Estimate against measurement, compound 4: 4.0-fold (0.60 log units) above; measured number below the stated range.
By their numbers in this assay, from the lowest: compounds 3 and 4 (each within the scatter of the next); then compounds 2 and 1 (each within the scatter of the next).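

In this assay, putting benzyl in place of 4-ethyl-2-methoxyphenoxy on a saturated chain carbon, three bonds along the chain from an amine nitrogen in a ring, gives no change at the digits printed from compound 3 to compound 4 (within the scatter) and stays level with the tightest binder in the set. For this pair, then, the hydrogen-bond acceptors and the ethyl of the leaving group are not required to keep this read-out, and a plain carbon-only group serves as well. Nothing shown here explains why the two groups read alike.

On these data alone, the whole group changes in one step, so the separate effects of the ethyl and the methoxy remain unknown, and they could even offset each other. Also open, as far as these compounds go, is how a carboxylic acid or an amine on the benzyl ring, or a longer chain at this place, would read.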